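A few compounds are considered here, and "the series" means these few. Any claim that something is new, unique, unknown or untested is made for them only; others in the source may bear on it.

Compound 1 `O=C(Nc1cc(C(F)(F)F)cc(C(F)(F)F)c1)c1ccc(Cl)cc1O` gives 200 nM in a functional assay on HL-60 cells (Homo sapiens) for cytotoxicity, read by luminescence and CellTiter-Glo, with a stated time of 3 days; a higher number here means a weaker inhibitor, a lower number a stronger inhibitor. Compound 2 `N#Cc1ccc(NC(=O)c2ccc3ccccc3c2O)cc1` gives 3410 nM in this assay. Compound 3 `Cc1cccc(O)c1C(=O)Nc1ccc(C#N)cc1` gives 6860 nM in this assay.

Among the three measured compounds, compound 3 stands at the highest number. Its nearest neighbour is compound 2, whose number is lower by an amount that lies within the scatter of this assay, so the two cannot be placed in any order. Compound 1 lies far below, well beyond the scatter, and is therefore the stronger inhibitor of the pair formed with compound 3.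

The step from compound 3 to compound 4 `COc1cccc(O)c1C(=O)Nc1ccc(C#N)cc1` is a single change: methoxy in place of methyl on an aromatic carbon. Within the data shown here, no measured pair shows the effect of this change in this assay, so nothing can be read from the data on its direction. Compound 4 is therefore expected to sit close to compound 3, with a step of a 1.1-fold lower number from compound 3 to compound 4 (0.06 log units; within the scatter) no larger than the scatter in either direction. The estimate for compound 4 in this assay is 6000 nM, with a range from 2500 nM to 14000 nM.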

Compound 4, half-maximal inhibitory concentration: > 10000 nM
Compound 4 gave a limit, no number (the forecaster's own chance of this, stated with the estimate: 10%); middle value at least 1.6-fold (0.22 log units) from the limit.
By their numbers in this assay, from the lowest: compound 1; then compounds 2 and 3 (each within the scatter of the next). At a limit, above all of these: compound 4.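

In this assay compound 4 gives a limit, not a number: the limit of > 10000 nM in this assay, at which 1 of the 4 values shown sits. As far as these compounds go, the data therefore put only a floor on this change, an at least 1.4-fold higher number from compound 3 to compound 4 (0.16 log units; that floor lies within the scatter), and the true size of the step stays unknown. Among these compounds, this is the first reading of methoxy in place of methyl on this aromatic carbon, ortho to a large group and meta to a hydroxy group, and it shows that the added oxygen and hydrogen-bond acceptor give no sign of a lower number at this position.

The compounds shown leave open how an amine, a chlorine or a longer chain such as ethoxy would read at this position. They also leave open whether methoxy in place of methyl would have the same outcome on the core of compound 1 or compound 2.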